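Hydroxy to Carboxy: One Change on a Shared Core

This account rests on a few compounds, and the source may have more. Where it says the series, first, only, none or still open, it means among the compounds named here.

Two compounds have been measured in a functional assay on A-375 cells (Homo sapiens) for antiproliferative activity, read by MTT assay, with a stated time of 24 h, tested at 33.33 ug/mL; a higher number here means a stronger effect of the compound at the concentration tested, a lower number a weaker effect:

Compound 1 `Cc1c(C(=O)Nc2c(F)cc(-c3cccc(F)c3)cc2F)nc2ccc(F)cc2c1O`: 28.8%
Compound 2 `Cc1c(C(=O)Nc2ccc(-c3ccccc3)cc2)nc2ccccc2c1O`: 34.3%

Compound 2 and compound 1 differ by an amount within the usual scatter, so compound 2 cannot be called the stronger of the two. Compound 3 `Cc1c(C(=O)Nc2ccc(-c3ccccc3)cc2)nc2ccccc2c1C(=O)O` has not yet been measured. It differs from compound 2 in one place: carboxy in place of hydroxy on an aromatic carbon. Going by the values given here, no measured pair shows this change, so its effect is unknown. In this assay a step of about a number 6.3 percentage points lower from compound 2 to compound 3 (within the scatter) is expected, downward if anything, and possibly not beyond the scatter. Compound 3 is estimated at 28%, within 10% to 48%.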

Compound 3, a percentage reported as inhibition, at one concentration (the size of the read-out at that concentration, not a potency): 25.6%
Estimate against measurement, compound 3: 2.4 percentage points above; measured number inside the range.
By their numbers in this assay, from the lowest: compounds 3, 1 and 2 (each within the scatter of the next).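

In this assay, carboxy in place of hydroxy on this aromatic carbon, opposite the ring nitrogen, gives a number 8.7 percentage points lower from compound 2 to compound 3 (within the scatter). This first measured pair for the change therefore cannot separate its effect from the usual scatter, even with two extra heavy atoms at a position ortho to a methyl group. No available evidence bears on this result.

The compounds shown leave open what an amine or a methoxy group would give on this carbon. They also leave open whether carboxy would read the same on the core of compound 1.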